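Adding a methoxy group to compound 1

The source may report more compounds than this note shows. Statements on the series, on what has been measured and on what is new or still open speak of the compounds shown alone.

In a functional assay on MOLT-4 cells (Homo sapiens) for antiproliferative activity, with a stated time of 48 h (a lower number here means a stronger inhibitor, a higher number a weaker inhibitor), compound 2 (`C=C(Br)C(=O)Nc1ccc(C(=O)/C=C/c2cccc(OC)c2)cc1`) gives 1100 nM and compound 1 (`C=C(Br)C(=O)Nc1ccc(C(=O)/C=C/c2ccc(OC)cc2)cc1`) gives 610 nM. For the measured compounds named here, these two values lie within the scatter of each other, so the measurements do not separate compound 1 from the only other compound tested. Compound 3 (`C=C(Br)C(=O)Nc1ccc(C(=O)/C=C/c2ccc(OC)cc2OC)cc1`) keeps the core of compound 1 with one change: methoxy in place of hydrogen on an aromatic carbon, ortho to a large group and meta to a methoxy group. Going by the values given here, the sole measured step exchanges 4-methoxyphenyl for 3-methoxyphenyl and adds no group. With only a 1.8-fold higher number from compound 1 to compound 2 (0.26 log units; within the scatter) to go on, no shift beyond the scatter is expected in this assay, in either direction. The expected change is a 1.1-fold higher number from compound 1 to compound 3 (0.06 log units; within the scatter). For compound 3 the estimate is 700 nM, with an expected range of 250 nM to 2000 nM.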

Compound 3, half-maximal inhibitory concentration: 1500 nM
Beside the measured number, compound 3's estimate is 2.1-fold (0.33 log units) below it, within the range that was stated.
By their numbers in this assay, from the lowest: compounds 1, 2 and 3 (each within the scatter of the next, the first and the last beyond it).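

In this assay, methoxy in place of hydrogen on an aromatic carbon, ortho to a large group and meta to a methoxy group, gives a 2.5-fold higher number from compound 1 to compound 3 (0.39 log units; beyond the scatter), a modest step. For the compounds shown here, the earlier step only moved a methoxy group and stayed within the scatter, whereas this one adds a group and is the first to pass beyond it, showing that this position is not indifferent to substitution in these cells. Nothing available bears on why the number rises.

Only hydrogen and methoxy are seen at this carbon, leaving open whether the rise belongs to methoxy itself or would follow any added group. A fluorine atom, a hydroxyl group or an amine at the same place would separate these readings, and ethoxy would show how a longer chain fares there.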